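Adding a Chloro Group to Compound 2

The source may hold more compounds than are shown below. What is called first, only, known or untested is meant among the compounds shown, and "the series" means these compounds.

For the measured compounds named here, in a physicochemical assay for solubility, in phosphate buffer, with a stated time of 2 h, at pH 7.4 (a lower number here means a less soluble compound, a higher number a more soluble compound), compound 2 (`Clc1ccc(Nc2nc(-c3ncccn3)cs2)nc1`) gives 20000 nM as the only actual number so far. Compound 1 (`Clc1ccc(Nc2nc(-c3ccccn3)c(Cl)s2)nc1`) reads < 10000 nM as its result, which is a limit of the assay and not a number. Compound 1 also carries a chloro group but lacks the pyrimidin-2-yl group.

Compound 3 (`Clc1ccc(Nc2nc(-c3ncccn3)c(Cl)s2)nc1`) is compound 2 with chloro in place of hydrogen on an aromatic carbon next to the ring sulfur. Going by the values given here, no measured pair shows this change alone, so its size in this assay is a matter of judgement. Among the compounds with values here, compound 1 is the only guide, and its limit of < 10000 nM as a result points to a fall rather than a rise. The estimated 2.5-fold lower number from compound 2 to compound 3 (0.40 log units; beyond the scatter) is a fall of modest size. For compound 3 the expected value is 8000 nM with a likely range from 3000 nM to 20000 nM in this measurement.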

Compound 3, solubility: < 10000 nM
Compound 3 was reported as a limit; the forecaster's own chance of this, stated with the estimate: 55%; the middle value is on the limit's open side.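

Chloro in place of hydrogen on an aromatic carbon, next to the ring sulfur, now has a direct pair in this assay, and it gives an at least 2.0-fold lower number from compound 2 to compound 3 (0.30 log units; that floor lies within the scatter). Compound 3 is reported as a limit and not a number, so this pair fixes only a floor for the change, not its full size. The step between compound 1 and compound 3 cannot be read, because both compounds sit at the same limit of the assay: the limit of < 10000 nM in this assay, at which 2 of the 3 values shown sit.

From the compounds shown here alone, how far the true value of compound 3 lies past that limit remains open, as does the real size of the chloro step. Also open, going by these compounds, is whether a methyl group, a fluoro atom or an amine on the same aromatic carbon would give a measurable number in this assay.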